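The compounds below may be only part of what the source reports. "The series", "measured", "known", "first", "only" and "open" are said of these compounds alone.

Working notes on the series. Compound 1 `C[C@H](NC(=O)c1cn(Cc2ccc(C(F)(F)F)cc2)nn1)c1ccc(C(=O)O)cc1` is tested in a functional assay on CHO cells for antagonist activity at prostaglandin E2 receptor EP4 subtype (Homo sapiens), read by calcium flux, with a stated time of 15 min; a lower number here means a stronger inhibitor, a higher number a weaker inhibitor. In this assay compound 1 gives > 10000 nM, which is a limit of the assay and not a number. Compound 2 `Cc1c(C(=O)N[C@@H](C)c2ccc(C(=O)O)cc2)nnn1Cc1ccc(C(F)(F)F)cc1` differs from compound 1 by methyl in place of hydrogen on an aromatic carbon. In this assay compound 2 gives > 10000 nM, again a limit. The step that the two limits leave unreadable from compound 1 to compound 2 is therefore not readable; this follows from the limit of > 10000 nM in this assay, at which 3 of the 3 values shown sit. Compound 3 `C[C@H](NC(=O)c1cnnn1Cc1ccc(C(F)(F)F)cc1)c1ccc(C(=O)O)cc1` has the same atoms as compound 1, joined differently; the difference between the two cores is not broken down here. In this assay compound 3 gives > 10000 nM, also a limit. Compound 4 `Cc1nnn(Cc2ccc(C(F)(F)F)cc2)c1C(=O)N[C@@H](C)c1ccc(C(=O)O)cc1` is not yet measured and differs from compound 3 by methyl in place of hydrogen on an aromatic carbon, the same kind of change as seen between compound 1 and compound 2, though around the place it sits next to the ring atom that bears a large group and two ring bonds from the ring atom that bears a large group, rather than next to two ring atoms that each bear a large group. The expectation for compound 4 rests on the step that the two limits leave unreadable from compound 1 to compound 2 and on the limit given for compound 3. Compound 4 is thus expected to make the step that the limit leaves unreadable from compound 3 to compound 4. Compound 4 is estimated at 20000 nM, between 5000 nM and 100000 nM.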

Compound 4, half-maximal inhibitory concentration: > 10000 nM
Compound 4 ended at the assay's limit; the forecaster's own chance of this, stated with the estimate: 85%; the middle value lies beyond the limit too.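

In this assay compound 4 gives > 10000 nM, a limit and not a number. No step can be read from compound 3 to compound 4, because both stand at a limit: the limit of > 10000 nM in this assay, at which 4 of the 4 values shown sit.

The compounds shown leave open what effect methyl in place of hydrogen has on either core, and how the two cores compare in this assay.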